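Swapping methyl for chloro on the aryl ether tail

A few compounds are considered here, and "the series" means these few. Any claim that something is new, unique, unknown or untested is made for them only; others in the source may bear on it.

The measured compounds and their values:
compound 1, `CC(C)C(=O)Nc1cccc(C2CCN(CCCC(=O)c3ccc(Cl)cc3)CC2)c1`: 5 nM
compound 2, `O=C(CCCN1CCC(c2cccc(NC(=O)C3CCCCC3)c2)CC1)c1ccc(Cl)cc1`: 200 nM
compound 3, `Cc1ccc(Oc2cccc(CN3CCC(c4cccc(NC(=O)C(C)C)c4)CC3)c2)cc1`: 31 nM

In an assay on isolated protein for displacement of a labelled ligand from melanin-concentrating hormone receptor 1 (Rattus norvegicus) (on this read-out higher numbers stand for weaker inhibition and lower numbers for stronger inhibition), compound 3 gives 31 nM, the second highest of the three numbers: compound 1 sits a clear step lower and compound 2 a clear step higher, so compound 3 stands in the middle. Compound 4, `CC(C)C(=O)Nc1cccc(C2CCN(Cc3cccc(Oc4ccc(Cl)cc4)c3)CC2)c1`, differs from compound 3 in one place: chloro in place of methyl on an aromatic carbon.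

Within the data shown here, the only measured step among the three compounds is a 40-fold higher number from compound 1 to compound 2 (1.60 log units; beyond the scatter), and it concerns the amide end of the molecule, far from the aryl ether tail where compound 4 is changed. Among the measured compounds shown here, no measured step touches the methyl-to-chloro swap, so there is no direct guide for the size of its effect. Without such a guide, the step from compound 3 to compound 4 in this assay is expected to stay small, a 1.0-fold lower number from compound 3 to compound 4 (0.01 log units; within the scatter), and could fall in either direction. The estimate for compound 4 is therefore 30 nM, with a range from 10 nM to 100 nM.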

Compound 4, inhibition constant: 23 nM
For compound 4 the middle estimate is 1.3-fold (0.12 log units) above the measured one, within the range that was stated.
By their numbers in this assay, from the lowest: compound 1; then compounds 4 and 3 (each within the scatter of the next); then compound 2.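

In this assay chloro in place of methyl on an aromatic carbon, para to a large group, comes with a 1.3-fold lower number from compound 3 to compound 4 (0.13 log units; within the scatter) and so the two groups cannot be told apart on this read-out. Among these compounds, the only earlier step, a 40-fold higher number from compound 1 to compound 2 (1.60 log units; beyond the scatter) at the amide end of the molecule, said nothing about the aryl ether tail, so this is the first reading at this position, and it shows that one single-atom group can stand in for the other there without a change beyond the scatter. No measured evidence bears on why the two groups read alike.

Going by these compounds, whether a larger or very different group, such as methoxy, a nitrile or a carboxylic acid, would also leave the number in place remains open. So does what plain hydrogen at this position would give.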